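The source may hold more compounds than are shown below. What is called first, only, known or untested is meant among the compounds shown, and "the series" means these compounds.

In an in vivo ADME assay on the whole organism for pharmacokinetics, with Rattus norvegicus as the target, at a dose of 3 mg/kg by the oral route (a higher number here means that a larger share of the oral dose reaches the circulation, a lower number that a smaller share of the oral dose reaches the circulation), compound 1 (`CN(C1CCCn2c1nc(C(=O)NCc1ccc(F)cc1)c(O)c2=O)S(C)(=O)=O`) gives 47% and compound 2 (`CN(C)S(=O)(=O)N(C)[C@@H]1CCCn2c1nc(C(=O)NCc1ccc(F)cc1)c(O)c2=O`) gives 63%, the higher of the two numbers, with a gap beyond the usual scatter. Compound 3 (`CN(C)S(=O)(=O)N(C)[C@H]1CCCn2c1nc(C(=O)NCc1ccc(F)cc1)c(O)c2=O`) changes only the spatial arrangement of compound 2: the two compounds have the same atoms and bonds and differ only in configuration as drawn: 1 of 1 stereo elements differ; a stereocentre at a saturated ring carbon is drawn R in compound 2 and S in compound 3. It has the same atoms and bonds, and a stereocentre at a saturated ring carbon is drawn R in compound 2 and S in compound 3. For the measured compounds named here, no measured pair yet shows what such a change does in this assay. The expected step is a slight fall, a number 5 percentage points lower from compound 2 to compound 3 (within the scatter), which would lie within the scatter. Compound 3 is expected at 58%, with an estimated range of 38% to 76%.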

Compound 3, oral bioavailability: 49%
Compound 3: middle estimate off by 9 percentage points, on the high side, and the stated range covers the measured number.
By their numbers in this assay, from the lowest: compounds 1 and 3 (each within the scatter of the next); then compound 2.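

In this assay, the configuration at this saturated ring carbon now proves able to change the result on its own, with R in compound 2 and S in compound 3: a number 14 percentage points lower from compound 2 to compound 3 (beyond the scatter). This step can be assigned to the stereocentre alone, because nothing else separates the two structures: the fact that compounds 2 and 3 differ only in the configuration as drawn. The compounds shown leave open whether the same change of configuration would give a similar step with a carboxylic acid or a simple amine on that carbon. They also do not show how the configuration alters the share of the oral dose reaching the circulation.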